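An Ester in Place of a Chloromethyl on the Acyl Chain

The compounds below may be only part of what the source reports. "The series", "measured", "known", "first", "only" and "open" are said of these compounds alone.

Compound 1 `CN1CCN(c2ccc(C3=NNC(c4ccc(N(C)C)cc4)C3)cc2)CC1` and compound 2 `CN1CCN(c2ccc(C3=NN(C(=O)CCCl)C(c4ccc(N(C)C)cc4)C3)cc2)CC1` share one core. In a functional assay on MDA-MB-231 cells (Homo sapiens) for inhibition, read by sulforhodamine B assay, tested at 10 uM (a higher number here means more inhibition at the concentration tested (going by the name of the read-out), a lower number less inhibition), compound 1 gives 11.4%. Compound 2 carries a (2-chloroethyl)carbonyl in place of hydrogen on an amine nitrogen in a ring, and in this assay compound 2 gives 2.4%, so that a number 9 percentage points lower from compound 1 to compound 2 (within the scatter); compound 2 thus sits within the scatter of compound 1. Compound 3 `COC(=O)CC(=O)N1N=C(c2ccc(N3CCN(C)CC3)cc2)CC1c1ccc(N(C)C)cc1` shows (methoxycarbonyl in place of chloromethyl on a saturated chain carbon bound to a carbonyl carbon). For the measured compounds named here, no measured step alters this part of the chain; the only step known, a number 9 percentage points lower from compound 1 to compound 2 (within the scatter), lies within the scatter, so no step beyond the scatter is expected in this assay. Compound 3 is estimated at 5%, ranging from -8% to 18%, an expected a number 2.6 percentage points higher from compound 2 to compound 3 (within the scatter).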

Compound 3, a percentage reported as inhibition, at one concentration (the size of the read-out at that concentration, not a potency): -0.4%
For compound 3 the middle estimate is 5.4 percentage points above the measured one; low and high end bracket the measured number.
By their numbers in this assay, from the lowest: compounds 3, 2 and 1 (each within the scatter of the next, the first and the last beyond it).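

In this assay, methoxycarbonyl in place of chloromethyl on a saturated chain carbon bound to a carbonyl carbon gives a number 2.8 percentage points lower from compound 2 to compound 3 (within the scatter), so the chlorine is not needed to hold the number at this level. For the compounds shown here, the whole acyl group, ((methoxycarbonyl)methyl)carbonyl in place of hydrogen on an amine nitrogen in a ring, gives a number 11.8 percentage points lower from compound 1 to compound 3 (beyond the scatter), the first step here to pass the scatter. No evidence at hand explains either step. On these data alone, whether an amine, a carboxylic acid or a longer chain at this position would give a number beyond the scatter of compound 3 remains open.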